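A few compounds are considered here, and "the series" means these few. Any claim that something is new, unique, unknown or untested is made for them only; others in the source may bear on it.

Compound 2 `Nc1ncc(-c2ccc(F)cc2)c(-c2ccccc2)n1` stands at the top of the numbers shown in an assay on CHO cells for displacement of a labelled ligand from adenosine receptor A1 (Homo sapiens), read by scintillation counting, with a stated time of 1 h, tested at 1 uM; a higher number here means more inhibition at the concentration tested (going by the name of the read-out), a lower number less inhibition: it gives > 80%, which is a limit of the assay rather than a number. Compound 1 `Cc1ccc(-c2cnc(N)nc2-c2ccccc2)cc1` gives 51% in this assay. The step of a number at least 29 percentage points higher from compound 1 to compound 2 (beyond the scatter) went with fluoro in place of methyl on an aromatic carbon and is capped by the limit of > 80% in this assay, at which 1 of the 2 values shown sits. Compound 3 `Nc1ncc(-c2ccc(Cl)cc2)c(-c2ccccc2)n1` differs from compound 2 by chloro in place of fluoro on an aromatic carbon. Among the compounds with values here, no measured step here involves chloro, so the only guide is that a small halogen at this place already reached the limit. For compound 3 the expected step is a step that the limit leaves unreadable from compound 2 to compound 3, within the scatter. Compound 3 is estimated at 85%, between 65% and 100%.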

Compound 3, a percentage reported as inhibition, at one concentration (the size of the read-out at that concentration, not a potency): 41%
Compound 3: middle estimate off by 44 percentage points, on the high side, and the stated range ends above it.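

In this assay, the halogen at this place is not interchangeable: chloro in place of fluoro gave a number at least 39 percentage points lower from compound 2 to compound 3 (beyond the scatter). Chloro in place of methyl gave a number 10 percentage points lower from compound 1 to compound 3 (within the scatter), so chloro and methyl are not told apart here, and among the three compounds only fluoro stands apart. The size of the fluoro gap stays open-ended: the limit of > 80% in this assay, at which 1 of the 3 values shown sits.

Open, from the compounds shown here alone, is whether bromo, methoxy or an amine at this place would read with fluoro or with chloro and methyl. Also open, going by these compounds, is the true level of compound 2, whose > 80% is a limit and not a number.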